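This account rests on a few compounds, and the source may have more. Where it says the series, first, only, none or still open, it means among the compounds named here.

Of the compounds shown here, two have so far been measured in a functional assay on the whole organism (strain Wistar) for inhibition, with Rattus norvegicus as the target, read by paw edema, with stated times of 30 min and 3 h, at a dose of 200 mg/kg by the oral route; on this read-out higher numbers stand for more inhibition at the one dose given (going by the name of the read-out) and lower numbers for less inhibition. Compound 1 `CC(=O)Nc1cc(-n2c(-c3ccccc3)cc3c2CCCC3)cc(C(=O)O)c1O` gives 0% in this assay, while compound 2 `COc1ccc(-c2cc3c(n2-c2ccc(O)c(C(=O)O)c2)CCCC3)cc1` gives 50%. Of these two numbers compound 2 stands highest, and its nearest neighbour is compound 1, whose value lies beyond the usual scatter below it.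

Compound 3 `O=C(O)c1cc(-n2c(-c3cccs3)cc3c2CCCC3)ccc1O` has not yet been measured in this assay. It differs from compound 2 in one place: thiophen-2-yl in place of 4-methoxyphenyl on an aromatic carbon. Among the compounds with values here, no pair of measured compounds shares this change, so the size of the step is uncertain. The step from compound 2 to compound 3 is estimated at a number 10 percentage points lower from compound 2 to compound 3 (within the scatter) in this assay, a moderate fall, although a step of no size beyond the scatter would not be surprising. Compound 3 is therefore expected to give about 40% in this assay, with a likely range from 15% to 65%.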

Compound 3, a percentage reported as inhibition, in the whole organism at one dose (the size of the read-out at that dose, not a potency): 30%
Compound 3: the middle estimate sits 10 percentage points above what was measured; low and high end bracket the measured number.
By their numbers in this assay, from the lowest: compound 1; then compound 3; then compound 2.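

In this assay, within the data shown here, placing thiophen-2-yl instead of 4-methoxyphenyl on the aromatic carbon next to the ring nitrogen gives a number 20 percentage points lower from compound 2 to compound 3 (beyond the scatter), the first comparison here in which only one place changes. This shows that the group at this position affects the read-out, yet the replacement does not abolish inhibition: compound 3 still gives 30%. Nothing measured here accounts for the fall.

The swap changes the ring size, brings in sulfur and removes the methoxy group all at once, so this single step cannot show which of these differences matters. From the compounds shown here alone, it also remains open how this position would respond to a furan-2-yl ring, a cyclohexyl ring or a simple methyl group, and each reading comes from a single dose, so it is not a measure of potency.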